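Swapping acetyl for dimethylamino on compound 1

This account rests on a few compounds, and the source may have more. Where it says the series, first, only, none or still open, it means among the compounds named here.

Of the compounds shown here, three have been measured in a functional assay on M14 cells (Homo sapiens) for cytotoxicity, read by sulforhodamine B assay, with a stated time of 48 h, tested at 0.001 uM; a lower number here means a stronger effect, a higher number a weaker effect of the compound at the concentration tested. Compound 1 `COc1cc(C)cc(-c2c(-c3ccnc(-c4ccc(C(C)=O)cc4)c3)cnn2CC#N)c1` gives 95% in this assay, the lowest of the three numbers, though it lies within the scatter of both others. Compound 2 `COc1cc(C)cc(-c2nn(CC#N)cc2-c2ccnc(-c3ccc(N(C)C)cc3)c2)c1` gives 96% in this assay, and compound 3 `Cc1cc(O)cc(-c2nn(CC#N)cc2-c2ccnc(-c3ccc(N(C)C)cc3)c2)c1` gives 96%. Going by the values given here, the one step among measured compounds that differ in a single place, no change at the digits printed from compound 2 to compound 3 (within the scatter), stayed flat. Compound 4 `COc1cc(C)cc(-c2c(-c3ccnc(-c4ccc(N(C)C)cc4)c3)cnn2CC#N)c1` has not yet been measured in this assay. It differs from compound 1 by dimethylamino in place of acetyl on an aromatic carbon. Among the compounds with values here, no measured step covers exactly this exchange; the only guidance is that compound 2, which also carries 4-(dimethylamino)phenyl on a differently arranged core, shows 96%, a number indistinguishable from compound 1 within the scatter, and that the single measured step was flat. The account therefore expects no change beyond the scatter, no change at the digits printed from compound 1 to compound 4 (within the scatter). Compound 4 is estimated to give 95% in this assay, with a range from 88% to 100%.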

Compound 4, a percentage reported as activity, at one concentration (the size of the read-out at that concentration, not a potency): 95%
Compound 4: middle estimate and measured number agree at the digits printed; low and high end bracket the measured number.
By their numbers in this assay, from the lowest: compounds 1, 4, 2 and 3 (each within the scatter of the next).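

Exchanging the acetyl of compound 1 for dimethylamino, on an aromatic carbon para to a large group, gives in this assay no change at the digits printed from compound 1 to compound 4 (within the scatter). The earlier single-place step concerned only a methyl on an oxygen on an aromatic ring; this one shows that, at the one concentration tested, 4-acetylphenyl and 4-(dimethylamino)phenyl cannot be told apart on the core of compound 1. Nothing is available here to explain why the read-out stays flat across this exchange.

From the compounds shown here alone, whether a carboxylic acid, a primary amine or a longer alkyl chain in this place would shift the number remains open. Going by these compounds, it also remains open whether compound 1 and compound 4 would separate at a higher concentration, since the read-out here offers no difference to compare.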